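From chloro to isopropyl on an aromatic carbon

The compounds below may be only part of what the source reports. "The series", "measured", "known", "first", "only" and "open" are said of these compounds alone.

For the measured compounds named here, in a functional assay on A549 cells (Homo sapiens) for antiproliferative activity, read by MTT assay, with a stated time of 48 h (on this read-out lower numbers stand for stronger inhibition and higher numbers for weaker inhibition), compound 2 (`O=C(/C=C/c1ccc(/C=C/C(=O)c2ccc(Cl)cc2)o1)NO`) gives 98100 nM, the highest of the two numbers so far, while compound 1 (`O=C(/C=C/c1ccc(/C=C/C(=O)c2ccccc2)o1)NO`) gives 20200 nM. Compound 3 (`CC(C)c1ccc(C(=O)/C=C/c2ccc(/C=C/C(=O)NO)o2)cc1`) has isopropyl in place of chloro on an aromatic carbon. Going by the values given here, the only measured step bearing on this change is a 4.9-fold higher number from compound 1 to compound 2 (0.69 log units; beyond the scatter), a modest one, with chloro in place of hydrogen. Among the compounds with values here, no measured compound carries isopropyl, so only a modest move to a lower number is expected. The expected step is a 2.2-fold lower number from compound 2 to compound 3 (0.34 log units; beyond the scatter). The estimated value for compound 3 is 45000 nM, within a range of 15000 nM to 110000 nM.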

Compound 3, half-maximal inhibitory concentration: 56700 nM
Estimate against measurement, compound 3: 1.3-fold (0.10 log units) below; the measured number falls inside the stated range.
By their numbers in this assay, from the lowest: compound 1; then compounds 3 and 2 (each within the scatter of the next).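

In this assay, isopropyl in place of chloro gives a 1.7-fold lower number from compound 2 to compound 3 (0.24 log units; within the scatter), so at this position the two groups cannot be told apart. Isopropyl in place of hydrogen gives a 2.8-fold higher number from compound 1 to compound 3 (0.45 log units; beyond the scatter), which shows that chloro is not alone: both groups on this aromatic carbon stand with a higher number than hydrogen. Nothing available gives a reason for this. The compounds shown leave open whether a methoxy group or an amine at this place would also give a higher number than hydrogen, or whether any group gives a lower one.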